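The source may report more compounds than this note shows. Statements on the series, on what has been measured and on what is new or still open speak of the compounds shown alone.

In a functional assay on cells (Splenocyte, Mus musculus, strain BALB/c) for inhibition, read by scintillation counting and thymidine incorporation, with a stated time of 72 h (a lower number here means a stronger inhibitor, a higher number a weaker inhibitor), compound 3 `CC(/C=N/Nc1ccc([N+](=O)[O-])cc1)=N\NC(=O)c1ccccc1I` gives 2980 nM. Its two neighbours, compound 1 `CC(/C=N/Nc1ccc([N+](=O)[O-])cc1)=N\NC(=O)c1ccccc1N` with 4900 nM and compound 2 `COc1cc(C(=O)N/N=C(C)/C=N/Nc2ccc([N+](=O)[O-])cc2)ccc1O` with 5100 nM, sit close by: the step of a 1.6-fold lower number from compound 1 to compound 3 (0.22 log units; within the scatter) and the step of a 1.7-fold lower number from compound 2 to compound 3 (0.23 log units; within the scatter) both stay inside the scatter, so the three cannot be told apart on these numbers.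

Compound 4 `CC(/C=N/Nc1ccc([N+](=O)[O-])cc1)=N\NC(=O)c1ccccc1Cl` differs from compound 3 in one place: chloro in place of iodo on an aromatic carbon. Among the measured compounds shown here, no measured step swaps one halogen for another; the nearest guide is a 1.6-fold lower number from compound 1 to compound 3 (0.22 log units; within the scatter), where a different group on the same aromatic carbon moved the number only within the scatter. On that basis the expected step is a 1.2-fold higher number from compound 3 to compound 4 (0.07 log units; within the scatter), essentially no change beyond the scatter. Compound 4 is therefore estimated at 3500 nM in this assay, expected between 1500 nM and 8000 nM.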

Compound 4, half-maximal inhibitory concentration: > 12000 nM
Compound 4 gave a limit, no number; the forecaster's own chance of this, stated with the estimate: 5%; at least 3.4-fold (0.53 log units) between middle value and limit.
By their numbers in this assay, from the lowest: compounds 3, 1 and 2 (each within the scatter of the next). At a limit, above all of these: compound 4.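

Compound 4 gives only a limit in this assay, not a number: the limit of > 12000 nM in this assay, at which 1 of the 4 values shown sits.
Amino and iodo on this aromatic carbon could not be told apart, but chloro in place of iodo gives an at least 4.0-fold higher number from compound 3 to compound 4 (0.60 log units; beyond the scatter) and so shows that this position, ortho to a large group, can respond to the group it carries. Compound 4 also separates from the other two compounds, with an at least 2.4-fold higher number from compound 1 to compound 4 (0.38 log units; beyond the scatter) and an at least 2.3-fold higher number from compound 2 to compound 4 (0.37 log units; beyond the scatter) in the same direction. From the compounds shown here alone, how bromo or fluoro would read on this carbon remains open. The limit also leaves open how far compound 4 truly lies from the others.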